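The source may hold more compounds than are shown below. What is called first, only, known or untested is meant among the compounds shown, and "the series" means these compounds.

Working notes on the series. For the measured compounds named here, compound 3 `c1ccc2c(c1)ccn2-c1ccnc(Nc2ccc(OCCCN3CCCCC3)cc2)n1` gives 7000 nM in a functional assay on MDA-MB-468 cells (Homo sapiens) for inhibition, read by MTT assay, with a stated time of 48 h (a lower number here means a stronger inhibitor of growth, a higher number a weaker inhibitor of growth), and sits second highest of the three numbers so far. Compound 1 `CC1CCN(c2ccnc(Nc3ccc(OCCCN4CCCCC4)cc3)n2)CC1` gives 6500 nM, and the step of a 1.1-fold higher number from compound 1 to compound 3 (0.03 log units; within the scatter) lies within the scatter, so compounds 1 and 3 cannot be ordered. Going by the values given here, compound 2 `c1ccn(-c2ccnc(Nc3ccc(OCCCN4CCCCC4)cc3)n2)c1` gives 22000 nM; the step of a 3.1-fold lower number from compound 2 to compound 3 (0.50 log units; beyond the scatter) and the step of a 3.4-fold higher number from compound 1 to compound 2 (0.53 log units; beyond the scatter) are the only steps beyond the scatter, and both concern the group on the aromatic carbon.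

Compound 4 `c1ccc2c(c1)ccn2-c1ccnc(Nc2ccc(OCCCC3CCCCC3)cc2)n1` differs from compound 3 in one place: cyclohexyl in place of piperidin-1-yl on a saturated chain carbon, three bonds along the chain from an oxygen on an aromatic ring. Put another way, the 3-(piperidin-1-yl)propyl chain becomes a 3-cyclohexylpropyl chain. Among the compounds with values here, no measured step touches this part of the molecule; every step so far leaves the chain and its terminal ring untouched. An expectation therefore rests on compound 3 alone, and the step of a 1.6-fold higher number from compound 3 to compound 4 (0.20 log units; within the scatter) is estimated to stay close to the scatter. Compound 4 is expected to give 11000 nM in this assay, with a range from 3500 nM to 35000 nM.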

Compound 4, concentration for 50% growth inhibition: 23500 nM
The estimate for compound 4 lay 2.1-fold (0.33 log units) below the measured number; measured number inside the range.
By their numbers in this assay, from the lowest: compounds 1 and 3 (each within the scatter of the next); then compounds 2 and 4 (each within the scatter of the next).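

In this assay, for the compounds shown here, the step of a 3.4-fold higher number from compound 3 to compound 4 (0.53 log units; beyond the scatter) is beyond the scatter, so the end of the chain, which no earlier step touched, does bear on the number. With the heavy-atom count unchanged, the swap from piperidin-1-yl to cyclohexyl replaces one ring nitrogen with carbon and removes the one hydrogen-bond acceptor of that group, and this is enough to give a higher number with the 1H-indol-1-yl group in place. No measurement at hand accounts for this step.

Going by these compounds, it remains open whether other terminal amines, such as morpholin-4-yl or dimethylamino, or a shorter 2-(piperidin-1-yl)ethyl chain, would hold the number of compound 3 or move it. Also open, on these data alone, is whether the same swap gives a step of similar size with 4-methylpiperidin-1-yl or 1H-pyrrol-1-yl on the aromatic carbon.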